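The compounds below may be only part of what the source reports. "The series", "measured", "known", "first", "only" and "open" are said of these compounds alone.

In a physicochemical assay for solubility, measured as thermodynamic solubility, at pH 7.4 (on this read-out lower numbers stand for lower solubility and higher numbers for higher solubility), compound 1 `Cc1[nH]ncc1-c1cncc(-c2ccc(C(N)=O)c(OC(C)C)c2)c1` gives 11 ug/mL and compound 2 `Cc1n[nH]c(C)c1-c1cncc(-c2ccc(C(N)=O)c(OC(C)C)c2)c1` gives 10 ug/mL, so compound 2 stands level with compound 1, within the scatter of repeat measurements. Compound 3 `CC(C)Oc1cc(-c2cccnc2)ccc1C(N)=O` differs from compound 2 by a much larger change, with hydrogen in place of 3,5-dimethyl-1H-pyrazol-4-yl on an aromatic carbon. Within the data shown here, only one measured step bears on this: a 1.1-fold lower number from compound 1 to compound 2 (0.04 log units; within the scatter), which is methyl in place of hydrogen on an aromatic carbon. That step concerns a single methyl on the group that leaves here, so it offers only a weak guide. Among the measured compounds shown here, no measured compound lacks the whole group, and the expected direction rests on the structural change alone. The expected step is a 4.0-fold higher number from compound 2 to compound 3 (0.60 log units; beyond the scatter), towards a higher number in this assay, and this is uncertain. For compound 3 the estimate is 40 ug/mL, with an expected range of 12 ug/mL to 150 ug/mL.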

Compound 3, solubility: 45 ug/mL
The estimate for compound 3 lay 1.1-fold (0.05 log units) below the measured number, and the stated range covers the measured number.
By their numbers in this assay, from the lowest: compounds 2 and 1 (each within the scatter of the next); then compound 3.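

Among these compounds, earlier, the only change at this part of the molecule was one methyl on the pyrazole, and it left the number within the scatter. In this assay, the whole group proves to matter: there is a 4.5-fold higher number from compound 2 to compound 3 (0.65 log units; beyond the scatter) when hydrogen replaces 3,5-dimethyl-1H-pyrazol-4-yl, and a 4.1-fold higher number from compound 1 to compound 3 (0.61 log units; beyond the scatter) when hydrogen replaces 5-methyl-1H-pyrazol-4-yl, so both steps lie beyond the scatter and point the same way. Nothing measured here explains the rise.

Still open, going by these compounds, is whether the entire ring must go, since a single methyl or an amine on this same aromatic carbon could give a number anywhere relative to these. On these data alone, a carboxylic acid or a morpholine ring at this place is equally open, and the two steps give no guide to where either would fall.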